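Hydroxy for methyl at the chain end of compound 2

The source may hold more compounds than are shown below. What is called first, only, known or untested is meant among the compounds shown, and "the series" means these compounds.

Compound 2 `CCCCCCCCN(C)C(=O)Cn1cc(Cc2cnc(=O)n(CC(=O)NCCC)c2)c(=O)nc1SCc1ccc(F)cc1` gives 42% in a functional assay on a cell-free system (plasma) for inhibition of platelet-activating factor acetylhydrolase (Homo sapiens), tested at 100 nM (a lower number here means less inhibition, a higher number more inhibition at the concentration tested (going by the name of the read-out)), the lower of the two numbers in hand; compound 1 `CCCCCCCCN(C)C(=O)Cn1cc(Cc2cnc(=O)n(CC(=O)NC)c2)c(=O)nc1SCc1ccc(F)cc1` gives 63%. Among the compounds with values here, the only measured step, a number 21 percentage points lower from compound 1 to compound 2 (beyond the scatter), changes the chain itself rather than its end group. Compound 3 `CCCCCCCCN(C)C(=O)Cn1cc(Cc2cnc(=O)n(CC(=O)NCCO)c2)c(=O)nc1SCc1ccc(F)cc1` differs from compound 2 by hydroxy in place of methyl on a saturated chain carbon, two bonds along the chain from an amide-type nitrogen. Within the data shown here, no measured step shows this kind of exchange, so it supports no expectation of a shift beyond the scatter; compound 3 is expected to lie near compound 2, with a number 3 percentage points higher from compound 2 to compound 3 (within the scatter) as the estimated step. Compound 3 is therefore estimated at 45%, within 25% to 65%.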

Compound 3, a percentage reported as inhibition, at one concentration (the size of the read-out at that concentration, not a potency): 68%
Compound 3: middle estimate off by 23 percentage points, on the low side; the measured number lies above the stated range.
By their numbers in this assay, from the lowest: compound 2; then compounds 1 and 3 (each within the scatter of the next).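

In this assay hydroxy in place of methyl brings a number 26 percentage points higher from compound 2 to compound 3 (beyond the scatter) and shows that the chain end counts here, not only the extension of the chain. Hydroxymethyl in place of hydrogen brings a number 5 percentage points higher from compound 1 to compound 3 (within the scatter) and shows that extension at this carbon need not cost inhibition, as ethyl did. The data at hand offer no explanation for this.

Going by these compounds, whether the hydroxy itself is required stays open: a methoxy, an amine or a carboxylic acid at the chain end, or a longer chain ending in hydroxy, would test this. Readings at one concentration also leave potency unresolved.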